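A few compounds are considered here, and "the series" means these few. Any claim that something is new, unique, unknown or untested is made for them only; others in the source may bear on it.

Measured so far in a physicochemical assay for lipophilicity; on this read-out lower numbers stand for lower lipophilicity and higher numbers for higher lipophilicity:
compound 1 `O=C1OCCN1c1cc(C(F)(F)F)ccc1[C@H]1CCOc2cc(S(=O)(=O)Nc3nccs3)ccc21`: 2.1
compound 2 `Cn1nccc1-c1cc(C(F)(F)F)ccc1[C@H]1CCOc2cc(S(=O)(=O)Nc3ncccn3)ccc21`: 3.7

Compound 1 is the lower of these two, and its gap to compound 2 lies beyond the scatter. Compound 3 `O=S(=O)(Nc1nccs1)c1ccc2c(c1)OCC[C@@H]2c1ccc(C(F)(F)F)cc1-c1ccc(F)cc1` keeps the core of compound 1 but has 4-fluorophenyl in place of 2-oxo-1,3-oxazolidin-3-yl on an aromatic carbon, ortho to a large group (4-fluorophenyl in place of 2-oxo-1,3-oxazolidin-3-yl on an aromatic carbon). Among the measured compounds shown here, no measured pair shows this exact swap, so the size of the step is a judgement. In this assay an upward move beyond the scatter is expected, a number 1.60 log units higher from compound 1 to compound 3 (beyond the scatter). The only other reference point is compound 2 at 3.7. For compound 3 the estimated value is 3.7, with an expected range from 3.1 to 4.3.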

Compound 3, distribution coefficient: 4.5
Beside the measured number, compound 3's estimate is 0.80 log units below it; the whole stated range lies below it.
By their numbers in this assay, from the lowest: compound 1; then compound 2; then compound 3.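

At this position, on an aromatic carbon ortho to a large group, this assay responds strongly to a single change: with 4-fluorophenyl in place of 2-oxo-1,3-oxazolidin-3-yl, there is a large step (a number 2.40 log units higher from compound 1 to compound 3 (beyond the scatter)). Among the compounds shown here, this is the first pair differing in only one place, so the size of the step can be tied to this swap alone. Nothing here shows what lies behind its size.

Going by these compounds, it remains open how much of the step depends on the fluorine, which a plain phenyl would test. On these data alone, it also remains open where an amine or a carboxylic acid at this position would fall.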